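The compounds below may be only part of what the source reports. "The series", "measured", "known", "first", "only" and "open" are said of these compounds alone.

Of the compounds shown here, two built on one shared core have been measured in a functional assay on M14 cells (Homo sapiens) for inhibition, read by sulforhodamine B assay, with a stated time of 48 h; a lower number here means a stronger inhibitor of growth, a higher number a weaker inhibitor of growth. Compound 1, `COc1cc(-c2nn(-c3cccc(NC(=O)c4ccc(Cl)c(C(F)(F)F)c4)c3)cc2-c2ccncc2)ccc1Cl`, gives 2790 nM in this assay. Compound 2, `O=C(Nc1cccc(-n2cc(-c3ccncc3)c(-c3ccc(Cl)c(O)c3)n2)c1)Nc1cc(C(F)(F)F)cc(C(F)(F)F)c1`, gives 607 nM in this assay. Compound 1 therefore holds the highest of the two numbers, and its nearest neighbour is compound 2, whose number lies lower by a gap beyond the usual scatter. These two differ in more than one place, so no single change can be credited with that gap.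

Compound 3, `COc1cc(-c2nn(-c3cccc(NC(=O)Nc4cccc(C(F)(F)F)c4)c3)cc2-c2ccncc2)ccc1Cl`, has not yet been measured. It differs from compound 1 in one place only: (3-(trifluoromethyl)phenyl)amino in place of 4-chloro-3-(trifluoromethyl)phenyl on a carbonyl carbon. Among the compounds with values here, no measured pair shows this change on its own. The account expects a move towards a lower number in this assay, of moderate size and possibly beyond the scatter, estimated as a 2.3-fold lower number from compound 1 to compound 3 (0.37 log units; beyond the scatter). Compound 3 is thus estimated at 1200 nM, within a range of 400 nM to 3500 nM in this assay.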

Compound 3, concentration for 50% growth inhibition: 754 nM
Compound 3: middle estimate off by 1.6-fold (0.20 log units), on the high side, within the range that was stated.
By their numbers in this assay, from the lowest: compounds 2 and 3 (each within the scatter of the next); then compound 1.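

On the carbonyl carbon of the shared core, in this assay, exchanging 4-chloro-3-(trifluoromethyl)phenyl for (3-(trifluoromethyl)phenyl)amino gives a 3.7-fold lower number from compound 1 to compound 3 (0.57 log units; beyond the scatter), so this position responds to the change by more than the usual scatter. Within the data shown here, this is the first single-place step, and it shows that the position tolerates the entering group, with its added nitrogen and hydrogen-bond donor, while growth inhibition strengthens modestly. Nothing measured here accounts for the step.

The step combines the gain of the nitrogen with the loss of the chlorine, and the compounds shown do not separate the two. On these data alone, that question stays open, as does the effect of (4-chloro-3-(trifluoromethyl)phenyl)amino, which keeps both the nitrogen and the chlorine, on this same carbonyl carbon.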